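Alkyl Growth at Two Positions on a Shared Core

The source may report more compounds than this note shows. Statements on the series, on what has been measured and on what is new or still open speak of the compounds shown alone.

Measured compounds
compound 1, `COc1ccc(-c2cc3c(cn2)[nH]c(=O)n3-c2cc(OC)c(OC)c(OC)c2)cc1F`: 2210 nM
compound 2, `CCOc1ccc(-c2cc3c(cn2)[nH]c(=O)n3-c2cc(OC)c(OC)c(OC)c2)cc1F`: 2870 nM
compound 3, `CCn1c(=O)n(-c2cc(OC)c(OC)c(OC)c2)c2cc(-c3ccc(OC)c(O)c3)ncc21`: > 20000 nM

Compounds 1 and 2 share a core and were tested in a functional assay on HeLa cells (Homo sapiens) for antiproliferative activity, read by MTT assay, with a stated time of 48 h; on this read-out higher numbers stand for weaker inhibition and lower numbers for stronger inhibition. Compound 1 gives 2210 nM in this assay, and compound 2 gives 2870 nM. The two differ in one place only, (methyl in place of hydrogen on a saturated chain carbon bound to an oxygen on an aromatic ring), and the step of a 1.3-fold higher number from compound 1 to compound 2 (0.11 log units; within the scatter) does not separate them.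

Compound 3 stands apart. In this assay compound 3 reaches only a limit, > 20000 nM, which is the limit of > 20000 nM in this assay, at which 1 of the 3 values shown sits. How the core of compound 3 differs from the core of compound 1 is not broken down here.

The not yet measured compound 4, `COc1ccc(-c2cc3c(cn2)n(C(C)C)c(=O)n3-c2cc(OC)c(OC)c(OC)c2)cc1O`, is related to compound 3 by methyl in place of hydrogen on a saturated chain carbon bound to an aromatic nitrogen and a saturated chain carbon. Among the compounds with values here, this is the same kind of change as the one from compound 1 to compound 2, but not the same: there the place was a saturated chain carbon bound to an oxygen on an aromatic ring, here it is a saturated chain carbon bound to an aromatic nitrogen and a saturated chain carbon. Within the data shown here, the one measured instance of such a change, a 1.3-fold higher number from compound 1 to compound 2 (0.11 log units; within the scatter), stayed within the scatter.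

On that basis the step from compound 3 to compound 4 is expected to be a step that the limit leaves unreadable from compound 3 to compound 4. Compound 4 is therefore estimated at 25000 nM in this assay, within 8000 nM to 80000 nM, and most likely it too will be reported only as a limit.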

Compound 4, half-maximal inhibitory concentration: 4240 nM
Beside the measured number, compound 4's estimate is 5.9-fold (0.77 log units) above it, outside the stated range (below it).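

In this assay the ethyl to isopropyl change gives an at least 4.7-fold lower number from compound 3 to compound 4 (0.67 log units; beyond the scatter), so a methyl addition that left no readable difference on the core of compound 1 does not behave the same way on the core of compound 3: the same change on two cores in this assay, a 1.3-fold higher number (0.11 log units; within the scatter) from compound 1 to compound 2 and an at least 4.7-fold lower number (0.67 log units; beyond the scatter) from compound 3 to compound 4, at least 6.1-fold (0.78 log units) apart, beyond the scatter of two such steps The value of compound 3, > 20000 nM, is a limit and not a number, which makes this step a bound and leaves its true size unread: the limit of > 20000 nM in this assay, at which 1 of the 4 values shown sits. The result does not show that the core alone decides the outcome, as the two steps also differ in place, one on a saturated chain carbon bound to an oxygen on an aromatic ring and the other on a saturated chain carbon bound to an aromatic nitrogen and a saturated chain carbon, and a single pair of steps sets no rule for carrying this change between cores in the series.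

The compounds shown leave open whether a longer chain such as butyl, or a chain ending in an amine, on that same aromatic nitrogen would go with a lower or a higher number than isopropyl does in compound 4. They also leave open how ethyl and isopropyl at that place would compare on the core of compound 1.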